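This account rests on a few compounds, and the source may have more. Where it says the series, first, only, none or still open, it means among the compounds named here.

Compound 1 `COc1cc(-c2cc(/C=C/C(=O)c3ccc(N)cc3)[nH]n2)cc(OC)c1OC` carries a 4-aminophenyl on a carbonyl carbon attached to its core. Among the measured compounds shown here, in a functional assay on NCI-H522 cells (Homo sapiens) for cytotoxicity, read by sulforhodamine B assay, with a stated time of 48 h, tested at 10 uM (on this read-out lower numbers stand for a stronger effect and higher numbers for a weaker effect at the one concentration tested), compound 1 gives -51%, the highest of the two numbers measured so far, which on this read-out means the weaker of the two effects. For the measured compounds named here, the only other measured compound, compound 2 `COc1ccc(-c2cc(/C=C/C(=O)c3ccc(N)cc3)[nH]n2)cc1`, gives -70% in this assay, a lower number and thus a stronger effect, and the gap between the two lies beyond the usual scatter. Compound 2 differs from compound 1 in more than one place, so no single-step lesson can be drawn from that pair.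

Compound 3 `COc1ccc(C(=O)/C=C/c2cc(-c3cc(OC)c(OC)c(OC)c3)n[nH]2)cc1OC` has not yet been measured. It keeps the core of compound 1 and differs from it in one place: 3,4-dimethoxyphenyl in place of 4-aminophenyl on a carbonyl carbon. Going by the values given here, no measured pair shows the effect of this exchange, so its direction cannot be read from the data at hand. Compound 3 is expected to stay close to compound 1, with a number 1 percentage points higher from compound 1 to compound 3 (within the scatter) not clearly beyond the scatter in either direction. The estimate for compound 3 in this assay is -50%, with a range from -80% to -15%.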

Compound 3, a percentage reported as activity, at one concentration (the size of the read-out at that concentration, not a potency): -95%
Estimate against measurement, compound 3: 45 percentage points above; measured number outside the range, below it.
By their numbers in this assay, from the lowest: compound 3; then compound 2; then compound 1.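

Among the compounds shown here, this is the first exchange whose effect can be read on its own. For the compounds shown here, only one place changes. In this assay, putting 3,4-dimethoxyphenyl in place of 4-aminophenyl on a carbonyl carbon gives a number 44 percentage points lower from compound 1 to compound 3 (beyond the scatter), and on this read-out a lower number stands for a stronger effect. The position is therefore far from indifferent: with the core of compound 1 held fixed, the group on the carbonyl carbon alone can move the result well past the usual scatter, and the swap replaces a group with one hydrogen-bond donor by a larger group with none. Nothing at hand says which of these differences accounts for the shift, as no measurement bears on its cause.

Going by these compounds, whether a single methoxy group would be enough remains open, as does how a plain phenyl or a 4-hydroxyphenyl would behave on the same carbonyl carbon. Also unsettled is whether the same exchange would give a step of similar size on the core of compound 2, which carries one methoxy group where compound 1 carries three.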